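A Ring Opened on the Chain Carbon Bound to Nitrogen

A few compounds are considered here, and "the series" means these few. Any claim that something is new, unique, unknown or untested is made for them only; others in the source may bear on it.

In a functional assay on cells for positive allosteric modulation of metabotropic glutamate receptor 2 (Homo sapiens), read by fluorescence and calcium flux, with a stated time of 30 min (on this read-out lower numbers stand for an effect already at smaller amounts and higher numbers for an effect only at larger amounts of compound), three compounds have been measured so far. Compound 1 `c1ccc(-c2ccc(Cn3nnc4ccccc43)cc2)cc1` gives 155 nM and compound 2 `Fc1cc(Cl)ccc1-c1ccc(Cn2nnc3ccccc32)nc1` gives 141 nM. Compound 3 `Brc1cccc2c1nnn2CC1CCC1` gives 20 nM, the lowest of the three numbers; the gaps from compound 3 to compound 2 and to compound 1 both lie beyond the usual scatter, so compound 3 is the most potent of the three in this assay. Compound 4 `CCCCn1nnc2c(Br)cccc21` differs from compound 3 in one place, (propyl in place of cyclobutyl on a saturated chain carbon bound to an aromatic nitrogen). Among the measured compounds shown here, no measured pair shows this change, so its effect has to be guessed. The step of a 1.5-fold higher number from compound 3 to compound 4 (0.18 log units; within the scatter) is expected to stay within the scatter, with at most a slight rise. Compound 4 is accordingly estimated at 30 nM, between 10 nM and 90 nM.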

Compound 4, half-maximal effective concentration: 60 nM
The estimate for compound 4 lay 2.0-fold (0.30 log units) below the measured number; the measured number falls inside the stated range.
By their numbers in this assay, from the lowest: compound 3; then compound 4; then compounds 2 and 1 (each within the scatter of the next).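

Among the compounds shown here, putting propyl in place of cyclobutyl on a saturated chain carbon bound to an aromatic nitrogen gives a 3.0-fold higher number from compound 3 to compound 4 (0.48 log units; beyond the scatter), the first step that can be read from a single change. It shows that this position responds to opening the ring, though the step is modest and the open chain keeps the effect. Nothing available explains this rise.

Still open, from the compounds shown here alone, is how a longer chain, a cyclopentyl ring or an amine would fare here. Going by these compounds, whether the same change would give a similar step on another core also remains unknown.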